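The compounds below may be only part of what the source reports. "The series", "measured", "known", "first", "only" and "open" are said of these compounds alone.

Compound 1 `Cc1cccc(NC(=O)C2(C(=O)Nc3ccc(Nc4ncc5cc(C(=O)N(C)C)n(C6CCCC6)c5n4)cc3)CC2)c1` is tested in a functional assay on A549 cells (Homo sapiens) for inhibition, read by CCK-8 assay, with a stated time of 72 h, tested at 10 uM (on this read-out higher numbers stand for more inhibition of growth at the one concentration tested and lower numbers for less inhibition of growth), where compound 1 gives 86.1%. Two close relatives are measured in the same way: compound 2 `CN(C)C(=O)c1cc2cnc(Nc3ccc(NC(=O)C4(C(=O)Nc5cccc(Cl)c5)CC4)cc3)nc2n1C1CCCC1` gives 90.7%, and compound 3 `COC(=O)c1cccc(NC(=O)C2(C(=O)Nc3ccc(Nc4ncc5cc(C(=O)N(C)C)n(C6CCCC6)c5n4)cc3)CC2)c1` gives 91%. Among these three numbers compound 1 holds the lowest, yet neither gap reaches beyond the scatter, so the three sit at much the same level.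

The compound not yet measured is compound 4 `CN(C)C(=O)c1cc2cnc(Nc3ccc(NC(=O)C4(C(=O)Nc5cccc(Br)c5)CC4)cc3)nc2n1C1CCCC1`. Compared with compound 1 the difference is bromo in place of methyl on an aromatic carbon. The most telling measured steps are those that also replace the methyl with a single small group: chloro gives a number 4.6 percentage points higher from compound 1 to compound 2 (within the scatter), methoxycarbonyl gives a number 4.9 percentage points higher from compound 1 to compound 3 (within the scatter), and between those two products the step is a number 0.3 percentage points higher from compound 2 to compound 3 (within the scatter). None of these moved the number beyond the scatter, and bromo is a halogen like chloro.

Compound 4 is therefore expected to change little in this assay, a step of about a number 3.9 percentage points higher from compound 1 to compound 4 (within the scatter), giving an estimated 90%, likely between 81% and 96%.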

Compound 4, percent growth inhibition at one concentration: 92.2%
Compound 4: the middle estimate sits 2.2 percentage points below what was measured, within the range that was stated.
By their numbers in this assay, from the lowest: compounds 1, 2, 3 and 4 (each within the scatter of the next).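

In this assay, bromo gives a number 6.1 percentage points higher from compound 1 to compound 4 (within the scatter), so a third replacement of the methyl on this aromatic ring leaves the number within the scatter. Bromo also cannot be separated from the other two replacements: swapping chloro for bromo gives a number 1.5 percentage points higher from compound 2 to compound 4 (within the scatter), and swapping methoxycarbonyl for bromo gives a number 1.2 percentage points higher from compound 3 to compound 4 (within the scatter), so the two halogens and the ester read alike at this position. Nothing measured here speaks to what lies behind this flat picture.

Still open, as far as these compounds go, is whether an amine, a carboxylic acid or a longer chain such as butoxy at this place would keep the number at the same level. Also open, from the compounds shown here alone, is whether these four compounds, indistinguishable at the one concentration tested, would separate at lower concentrations.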